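The compounds below may be only part of what the source reports. "The series", "measured", "known", "first", "only" and "open" are said of these compounds alone.

Working notes on the series. Compound 1 `COc1c(C(=O)c2ccc3c(c2)C(C)(C)CCC3(C)C)ccc2cc(C(=O)O)ccc12` gives 0% in an assay on isolated protein with retinoic acid receptor beta (Homo sapiens) as the target; on this read-out higher numbers stand for larger maximal responses and lower numbers for smaller maximal responses. Compound 2 `CC1(C)CCC(C)(C)c2cc(C(O)c3ccc4cc(C(=O)O)ccc4c3)c(O)cc21` gives 18%, and compound 3 `Cc1cc2c(cc1C(O)c1ccc3cc(C(=O)O)ccc3c1)C(C)(C)CCC2(C)C` gives 96%, the highest of the three numbers; its nearest neighbour is compound 2 and the furthest is compound 1, both beyond the scatter. Within the data shown here, the single one-place step in the set, a number 78 percentage points higher from compound 2 to compound 3 (beyond the scatter), shows that the group on this aromatic carbon can move the maximal response strongly.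

Compound 4 `CC1(C)CCC(C)(C)c2cc(C(O)c3ccc4cc(C(=O)O)ccc4c3)c(F)cc21` differs from compound 3 as follows: fluoro in place of methyl on an aromatic carbon. Among the measured compounds shown here, no measured step in the set exchanges methyl for fluoro, so the only bearing comes from compound 2 and compound 3, whose difference a number 78 percentage points higher from compound 2 to compound 3 (beyond the scatter) marks this position as sensitive. A drop from compound 3 is therefore expected, of uncertain size, in a number 36 percentage points lower from compound 3 to compound 4 (beyond the scatter). For compound 4 the expected value is 60%, with a range from 20% to 100%.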

Compound 4, largest response reached (reported as maximum), in percent of the reference or control that the assay uses: 30%
Beside the measured number, compound 4's estimate is 30 percentage points above it; the range from low to high includes it.
By their numbers in this assay, from the lowest: compound 1; then compound 2; then compound 4; then compound 3.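

Exchanging methyl for fluoro on this aromatic carbon gives a number 66 percentage points lower from compound 3 to compound 4 (beyond the scatter) in this assay, so the high response of compound 3 does not carry over to this equally small substituent. Fluoro in place of hydroxy gives only a number 12 percentage points higher from compound 2 to compound 4 (beyond the scatter), which leaves compound 4 much closer to compound 2 than to compound 3. Among the three groups read at this place, the response rises from hydroxy to fluoro to methyl, with the largest step at the last exchange.

As far as these compounds go, whether the high response extends to other groups remains open, and chloro, ethyl or an amine on the same carbon would test this. The information at hand offers no explanation for this order.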